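Toward Compound 3: Expected Step from an Amide Change

The source may hold more compounds than are shown below. What is called first, only, known or untested is meant among the compounds shown, and "the series" means these compounds.

Measured compounds:
compound 1 `COc1cc(-c2nn(-c3cccc(NC(=O)c4ccc(Cl)c(C(F)(F)F)c4)c3)cc2-c2ccncc2)ccc1Cl`, 11200 nM
compound 2 `O=C(Nc1cccc(-n2cc(-c3ccncc3)c(-c3ccc(Cl)c(O)c3)n2)c1)Nc1cc(C(F)(F)F)cc(C(F)(F)F)c1`, 5250 nM

In a functional assay on NCI/ADR-RES cells (Homo sapiens) for inhibition, read by sulforhodamine B assay, with a stated time of 48 h (a higher number here means a weaker inhibitor of growth, a lower number a stronger inhibitor of growth), compound 1 gives 11200 nM, the highest of the two numbers in hand. Compound 2 gives 5250 nM in this assay, a lower number, and the gap between the two lies beyond the usual scatter. Compound 2 differs from compound 1 in more than one place, so no single structural change is tied to a measured step here.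

Compound 3 `COc1cc(-c2nn(-c3cccc(NC(=O)Nc4ccc(Cl)c(Cl)c4)c3)cc2-c2ccncc2)ccc1Cl` has not yet been measured in this assay. It differs from compound 1 in one place: (3,4-dichlorophenyl)amino in place of 4-chloro-3-(trifluoromethyl)phenyl on a carbonyl carbon. For the measured compounds named here, with no measured single-change step to lean on, the expectation rests on compound 2 having the lower number. Compound 3 is estimated at 6500 nM, with a range from 2500 nM to 15000 nM. The step expected is a 1.7-fold lower number from compound 1 to compound 3 (0.24 log units; within the scatter), a modest move toward a lower number, though one that could still fall within the scatter.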

Compound 3, concentration for total growth inhibition: 4670 nM
Beside the measured number, compound 3's estimate is 1.4-fold (0.14 log units) above it; low and high end bracket the measured number.
By their numbers in this assay, from the lowest: compounds 3 and 2 (each within the scatter of the next); then compound 1.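

In this assay, the change on the carbonyl carbon gives the first measured step in one place among these compounds, with (3,4-dichlorophenyl)amino in place of 4-chloro-3-(trifluoromethyl)phenyl: a 2.4-fold lower number from compound 1 to compound 3 (0.38 log units; beyond the scatter). It shows that the number responds to a change at this position, on a carbonyl carbon whose other neighbours are an amide-type nitrogen, by a modest step that lies beyond the scatter. Nothing at hand accounts for this step.

The compounds shown do not separate the entering amino nitrogen from the change among the groups on the aromatic ring, so it remains open which of these goes with the lower number. Also open, on these data alone, is how this position would read with a methylene group in place of that nitrogen, or with bromine in place of either chlorine.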